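The source may report more compounds than this note shows. Statements on the series, on what has been measured and on what is new or still open speak of the compounds shown alone.

Compound 1 `C#CCOc1ccc2c(=O)c(-c3cc(OC)c(OC)cc3OC)coc2c1` is one of three compounds with a reading so far. In a functional assay on HUVEC cells (Homo sapiens) for antiproliferative activity, read by MTT assay, with a stated time of 24 h (on this read-out higher numbers stand for weaker inhibition and lower numbers for stronger inhibition), compound 1 gives > 10000 nM, which is a limit of the assay and not a number. Compound 2 `COc1ccc2c(=O)c(-c3cc(OC)c(OC)cc3OC)coc2c1` in this assay gives > 10000 nM, again a limit. Within the data shown here, compound 3 `COc1cc(OC)c(-c2coc3cc(OCc4ccccc4C)ccc3c2=O)cc1OC` in this assay gives 4830 nM, the only measured number of the set. Compound 1 therefore stands at the limit of > 10000 nM in this assay, at which 2 of the 3 values shown sit, and the step that the two limits leave unreadable from compound 1 to compound 2 cannot be read from the two limits. The step of an at least 2.0-fold lower number from compound 1 to compound 3 (0.31 log units; beyond the scatter) and the step of an at least 2.0-fold lower number from compound 2 to compound 3 (0.31 log units; beyond the scatter) both point to a lower number once a substituted benzyl takes the place of the smaller group.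

Compound 4 `COc1cc(OC)c(-c2coc3cc(OCc4cccc(Br)c4)ccc3c2=O)cc1OC` differs from compound 1 by 3-bromophenyl in place of ethynyl on a saturated chain carbon bound to an oxygen on an aromatic ring. Read one bond further out, this is propargyloxy to (3-bromobenzyl)oxy, the same kind of exchange as from compound 1 to compound 3, so the step of an at least 2.0-fold lower number from compound 1 to compound 3 (0.31 log units; beyond the scatter) is the one that bears on it and a step of at least similar size in this assay, towards a lower number, is expected. Compound 4 is therefore estimated at 4500 nM, with a range from 1500 nM to 15000 nM, which means an expected step of an at least 2.2-fold lower number from compound 1 to compound 4 (0.34 log units; beyond the scatter).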

Compound 4, half-maximal inhibitory concentration: > 10000 nM
Compound 4: a limit, no number; the forecaster's own chance of this, stated with the estimate: 30%; middle value at least 2.2-fold (0.34 log units) away from the limit.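

In this assay compound 4 stays at a limit of the assay and not a number, which shows that a benzyl-type group at this position does not by itself bring a measurable reading: the limit of > 10000 nM in this assay, at which 3 of the 4 values shown sit.

Until now, the only substituted benzyl shown had given a number, but exchanging 2-methylphenyl for 3-bromophenyl on the saturated chain carbon gives an at least 2.0-fold higher number from compound 3 to compound 4 (0.31 log units; beyond the scatter). The outcome therefore depends on the substituted ring that enters and not merely on an aromatic ring taking the place of the smaller groups, while the steps from compound 1 and from compound 2 to compound 4 cannot be read, with a limit at both ends.

Compound 3 and compound 4 differ both in the substituent and in where it sits on the ring, so the compounds shown cannot separate these two changes, and neither 3-methylbenzyl nor 2-bromobenzyl is among them to do so. Among these compounds, how the plain unsubstituted benzyl would read also stays open, and compound 3 remains the only compound with a measured number.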